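Ring Size at One Carbon: From Cycloheptyl to Cyclooctyl

The source may hold more compounds than are shown below. What is called first, only, known or untested is meant among the compounds shown, and "the series" means these compounds.

- compound 1 `CCCCCC1(c2ccc(O)cc2)C(=O)Nc2c1ccc(F)c2F`: 1.1 nM
- compound 2 `O=C1Nc2c(ccc(F)c2F)C1(c1ccc(O)cc1)C1CCCC1`: 8.2 nM
- compound 3 `O=C1Nc2c(ccc(F)c2F)C1(c1ccc(O)cc1)C1CCCCCC1`: 12 nM

These three values come from a functional assay on PC-3 cells (Homo sapiens) for cytotoxicity, read by WST assay, with a stated time of 72 h; a higher number here means a weaker inhibitor, a lower number a stronger inhibitor. The compounds share one core and differ only in the group on a saturated ring carbon, which is pentyl in compound 1, cyclopentyl in compound 2 and cycloheptyl in compound 3.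

Compound 3 stands with compound 2 at the weaker end of this small set. The two cannot be told apart, as the measured change is a 1.5-fold higher number from compound 2 to compound 3 (0.17 log units; within the scatter). Both are clearly weaker than compound 1, with a 7.5-fold higher number from compound 1 to compound 2 (0.87 log units; beyond the scatter) and an 11-fold higher number from compound 1 to compound 3 (1.04 log units; beyond the scatter).

The next compound, compound 4 `O=C1Nc2c(ccc(F)c2F)C1(c1ccc(O)cc1)C1CCCCCCC1`, has cyclooctyl in place of cycloheptyl on a saturated ring carbon.

The closest guide is the change from cyclopentyl to cycloheptyl, because it stayed as small as a 1.5-fold higher number from compound 2 to compound 3 (0.17 log units; within the scatter). The two larger steps replace an open chain with a ring, so they bear less on this change. With only these rings to go on, no clear shift in either direction is expected, and the number may drift slightly upward.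

The expected change is a 1.2-fold higher number from compound 3 to compound 4 (0.07 log units; within the scatter).

For compound 4 the estimated value is 14 nM, with an expected range from 5 nM to 40 nM.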

Compound 4, half-maximal inhibitory concentration: > 1000 nM
Compound 4 was reported as a limit; the forecaster's own chance of this, stated with the estimate: 2%; at least 71-fold (1.85 log units) between middle value and limit.
By their numbers in this assay, from the lowest: compound 1; then compounds 2 and 3 (each within the scatter of the next). At a limit, above all of these: compound 4.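

Compound 4 is reported only as a limit and not as a number: the limit of > 1000 nM in this assay, at which 1 of the 4 values shown sits. Even so, it shows that ring size at this saturated ring carbon does not follow a smooth trend in this assay: cyclopentyl and cycloheptyl could not be told apart, yet cyclooctyl in place of cycloheptyl gives an at least 83-fold higher number from compound 3 to compound 4 (1.92 log units; beyond the scatter). The gap is just as clear against the other two groups, with an at least 120-fold higher number from compound 2 to compound 4 (2.08 log units; beyond the scatter) and an at least 900-fold higher number from compound 1 to compound 4 (2.95 log units; beyond the scatter), so among these four compounds the sharp loss belongs to cyclooctyl alone, and the earlier ring change gave no warning of it.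

The compounds shown leave open how far beyond the limit compound 4 really lies, and they give no reason for so abrupt a change. They also leave open whether cyclohexyl, a longer chain such as octyl, or a cycloheptyl ring carrying an amine would stay with compound 2 and compound 3 or fall away as compound 4 does.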